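Third Fluorine on the Phenoxy Tail of Compound 3

This account rests on a few compounds, and the source may have more. Where it says the series, first, only, none or still open, it means among the compounds named here.

compound 1: `NC(=O)c1ccn(-c2cccc(OC(=O)NCCOCCOc3ccccc3)c2)c1` gives 23 nM in an assay (brain) for inhibition of Fatty-acid amide hydrolase 1 (Mus musculus), with stated times of 20 min and 15 min; on this read-out lower numbers stand for stronger inhibition and higher numbers for weaker inhibition
compound 2: `NC(=O)c1ccn(-c2cccc(OC(=O)NCCOCCOc3ccccc3F)c2)c1` gives 18 nM in this assay
compound 3: `NC(=O)c1ccn(-c2cccc(OC(=O)NCCOCCOc3ccc(F)cc3F)c2)c1` gives 7 nM in this assay

Compound 3 stands lowest of the three numbers in this assay. Its nearest neighbour is compound 2, with a 2.6-fold lower number from compound 2 to compound 3 (0.41 log units; beyond the scatter), and compound 1 lies furthest away, with a 3.3-fold lower number from compound 1 to compound 3 (0.52 log units; beyond the scatter). Both gaps lie beyond the scatter, so compound 3 is the strongest inhibitor among the three measured.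

Compound 4 `NC(=O)c1ccn(-c2cccc(OC(=O)NCCOCCOc3c(F)cc(F)cc3F)c2)c1` differs from compound 3 by one change: fluoro in place of hydrogen on an aromatic carbon. The new fluoro sits on an aromatic carbon of the six-membered ring of carbon only, ortho to a large group and meta to two fluoro groups, turning 2,4-difluorophenoxy into 2,4,6-trifluorophenoxy.

Two measured steps are of the same kind. The first fluoro gave a 1.3-fold lower number from compound 1 to compound 2 (0.11 log units; within the scatter), which is within the scatter. The second gave a 2.6-fold lower number from compound 2 to compound 3 (0.41 log units; beyond the scatter), a modest gain. A third fluoro is therefore expected to leave the number unchanged or to lower it modestly; the expected step is a 1.4-fold lower number from compound 3 to compound 4 (0.15 log units; within the scatter). Compound 4 is estimated at 5 nM in this assay, with a range from 2.5 nM to 12 nM.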

Compound 4, inhibition constant: 11 nM
For compound 4 the middle estimate is 2.2-fold (0.34 log units) below the measured one, within the range that was stated.
By their numbers in this assay, from the lowest: compounds 3, 4, 2 and 1 (each within the scatter of the next, the first and the last beyond it).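

In this assay, placing a fluoro on the aromatic carbon ortho to a large group and meta to two fluoro groups gives a 1.6-fold higher number from compound 3 to compound 4 (0.20 log units; within the scatter), so this position accepts the atom with no shift that can be told from the scatter, and the modest gain from the previous fluoro is not extended. The 2,4,6-trifluorophenoxy tail also shows a 1.6-fold lower number from compound 2 to compound 4 (0.21 log units; within the scatter), again no separable shift, while against the plain phenoxy tail it shows a 2.1-fold lower number from compound 1 to compound 4 (0.32 log units; beyond the scatter), so a modest advantage over the unsubstituted ring remains with all three fluoro groups in place. Apart from a 2.6-fold lower number from compound 2 to compound 3 (0.41 log units; beyond the scatter), the change of hydrogen to fluoro on this tail stays small, and its two small readings agree with each other: the same change on two cores in this assay, a 1.3-fold lower number (0.11 log units; within the scatter) from compound 1 to compound 2 and a 1.6-fold higher number (0.20 log units; within the scatter) from compound 3 to compound 4, 2.0-fold (0.30 log units) apart, within the scatter of two such steps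

The compounds shown leave open how this same position would respond to a chloro, a methyl or a methoxy group in place of the fluoro. They also leave open whether the 2,4,6-trifluorophenoxy tail would read the same with a longer chain joining it to the shared core.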